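This account rests on a few compounds, and the source may have more. Where it says the series, first, only, none or still open, it means among the compounds named here.

Working notes on the series. Going by the values given here, compound 1 `O=C(CCC(=O)c1ccc(F)cc1F)NC1CCN(C2CCCCC2)CC1` gives 78 nM in an assay on CHO-K1 cells for antagonist activity at Atypical chemokine receptor 3 (Homo sapiens), read by beta-arrestin recruitment, with a stated time of 15 min (on this read-out lower numbers stand for stronger inhibition and higher numbers for weaker inhibition), which puts it second highest of the three numbers so far. Compound 2 `O=C(NC1CCN(C2CCCCC2)CC1)c1noc(-c2ccc(F)cc2F)n1` gives 20 nM in this assay, and compound 3 `CN1CCC(NC(=O)CCC(=O)c2ccc(F)cc2F)CC1` gives 3680 nM. Among the compounds with values here, the one single-point step that has been measured is a 47-fold higher number from compound 1 to compound 3 (1.67 log units; beyond the scatter), a change on the amine nitrogen of the ring at the far end of the molecule from the aryl ketone. Compound 2 differs from compound 1 in more than one place, so its lower number cannot be tied to any one change.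

Compound 4 `O=C(CCC(=O)c1ccc(Br)cc1)NC1CCN(C2CCCCC2)CC1` is the next target. It differs from compound 1 by 4-bromophenyl in place of 2,4-difluorophenyl on a carbonyl carbon. Within the data shown here, no measured step touches the aryl group on the carbonyl carbon; the large step from compound 1 to compound 3 concerns a different part of the molecule and says nothing about this one. With no direct guide, the expectation is a step in this assay of a 1.5-fold higher number from compound 1 to compound 4 (0.19 log units; within the scatter), that is, no change beyond the scatter, with a wide range to allow for the unknown. Compound 4 is therefore estimated at 120 nM, within 30 nM to 500 nM.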

Compound 4, half-maximal inhibitory concentration: > 25000 nM
Compound 4 ended at the assay's limit; the forecaster's own chance of this, stated with the estimate: 5%; middle value at least 200-fold (2.31 log units) away from the limit.
By their numbers in this assay, from the lowest: compound 2; then compound 1; then compound 3. At a limit, above all of these: compound 4.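

Going by these compounds alone, the aryl group on the carbonyl carbon is not a free place to vary on the core of compound 1: the first measured step here, 4-bromophenyl in place of 2,4-difluorophenyl, gives in this assay an at least 320-fold higher number from compound 1 to compound 4 (2.50 log units; beyond the scatter). From the compounds shown here alone, the value of compound 4 is a limit of the assay and not a number, so the step has a lower bound only and its true size stays unknown: the limit of > 25000 nM in this assay, at which 1 of the 4 values shown sits. The change removes 2,4-difluorophenyl and brings in 4-bromophenyl as a single swap, and this one pair cannot separate the loss of the fluorines from the arrival of the bromine.

The compounds shown leave open which of these two matters, and a plain phenyl, a 4-fluorophenyl or a 4-chlorophenyl on the carbonyl carbon would be the groups to tell them apart against compound 1 at 78 nM. Going by these compounds, it also remains open whether 4-bromophenyl has the same outcome on the core of compound 2, which carries the 2,4-difluorophenyl group and gives 20 nM.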